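The source may report more compounds than this note shows. Statements on the series, on what has been measured and on what is new or still open speak of the compounds shown alone.

Measured compounds:
compound 1 `COC(=O)c1ccc(Cc2c3c(n(CC(=O)O)c2C)CCNC3=O)c(S(=O)(=O)c2ccccc2)c1`: 11 nM
compound 2 `Cc1c(Cc2cc(F)ccc2S(=O)(=O)c2ccccc2)c2c(n1CC(=O)O)CCNC2=O`: 3.7 nM
compound 3 `CNC(=O)c1cccc(S(=O)(=O)c2ccccc2Cc2c3c(n(CC(=O)O)c2C)CCNC3=O)c1`: 240 nM

In a functional assay on CHO.K1 cells for antagonist activity at prostaglandin D2 receptor 2 (Homo sapiens), read by GTPgammaS binding, with a stated time of 1 h (on this read-out lower numbers stand for stronger inhibition and higher numbers for weaker inhibition), compound 3 gives 240 nM, the highest of the three numbers, beyond the scatter from compound 1 and from compound 2. Compound 4 `Cc1c(Cc2ccccc2S(=O)(=O)N(C)Cc2ccccc2)c2c(n1CC(=O)O)CCNC2=O` differs from compound 3 by benzyl(methyl)amino in place of 3-(methylcarbamoyl)phenyl on a sulfonyl sulfur. Among the measured compounds shown here, no step between measured compounds matches this change, so its size is uncertain. Compound 1, which also lacks the methylcarbamoyl group, gives 11 nM, and compound 2 gives 3.7 nM; both stand well below compound 3. On that basis the step from compound 3 to compound 4 is expected to be a 6.0-fold lower number from compound 3 to compound 4 (0.78 log units; beyond the scatter), toward a lower number and beyond the scatter. Compound 4 is expected to give 40 nM, within a range of 8 nM to 200 nM.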

Compound 4, half-maximal inhibitory concentration: 26 nM
For compound 4 the middle estimate is 1.5-fold (0.19 log units) above the measured one; the range from low to high includes it.
By their numbers in this assay, from the lowest: compound 2; then compound 1; then compound 4; then compound 3.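

a 9.2-fold lower number from compound 3 to compound 4 (0.97 log units; beyond the scatter) in this assay, so the sulfonyl sulfur carries an amino substituent, benzyl(methyl)amino, as well as an aromatic carbon and still gives a lower number. The step swaps 3-(methylcarbamoyl)phenyl for a group with no hydrogen-bond donor or acceptor, and the number falls beyond the scatter. No measurement on hand accounts for this step.

A single step cannot separate the loss of the methylcarbamoyl group from the new nitrogen on sulfur. Open too, on these data alone, is how dimethylamino or piperidine on that sulfur would read.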